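Cyclopropyl for 4-Fluorobenzyl on the Amide Nitrogen

The source may report more compounds than this note shows. Statements on the series, on what has been measured and on what is new or still open speak of the compounds shown alone.

Compound 1 `COC(=O)C[C@H](NC(=O)OC(C)(C)C)C(=O)N(Cc1ccc(F)cc1)C1(C(=O)NCc2ccccc2)CCN(Cc2ccccc2)CC1` was examined in an ADME assay on MDCK cells (Canis lupus familiaris) for cytotoxicity, read by microscopy, with a stated time of 72 h; on this read-out higher numbers stand for lower toxicity in this test and lower numbers for higher toxicity in this test. In this assay compound 1 gives > 100000 nM, which is a limit of the test and not a number. Compound 2 `COC(=O)C[C@H](NC(=O)OC(C)(C)C)C(=O)N(Cc1ccc(F)cc1)C1(C(=O)NC(C)(C)C)CCN(Cc2ccccc2)CC1` gives 80000 nM in this assay. Among the compounds with values here, the only measured step, an at least 1.2-fold lower number from compound 1 to compound 2 (0.09 log units; that floor lies within the scatter), puts tert-butyl in place of benzyl on an amide-type nitrogen, and its size stays within the scatter; the starting point of that step sits at the limit of > 100000 nM in this assay, at which 1 of the 2 values shown sits.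

Compound 3 `COC(=O)C[C@H](NC(=O)OC(C)(C)C)C(=O)N(C1CC1)C1(C(=O)NCc2ccccc2)CCN(Cc2ccccc2)CC1` has not yet been measured in this assay. It differs from compound 1 in one place: cyclopropyl in place of 4-fluorobenzyl on an amide-type nitrogen. Within the data shown here, no measured step touches this amide-type nitrogen, and the single step that is known left the read-out within the scatter. Compound 3 is therefore expected to show no movement beyond the scatter, a number no higher from compound 1 to compound 3 (the limit leaves the size open). Compound 3 is estimated at 100000 nM, within a range from 50000 nM to 200000 nM, with a fair chance that this assay again reports only a limit.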

Compound 3, minimum cytotoxic concentration: 84000 nM
Compound 3: middle estimate off by 1.2-fold (0.08 log units), on the high side; low and high end bracket the measured number.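

Within the data shown here, the step at this position, an at least 1.1-fold lower number from compound 1 to compound 3 (0.07 log units; that floor lies within the scatter), is the first reading on the amide-type nitrogen whose other neighbours are the carbonyl carbon and the saturated ring carbon. Here a six-membered aromatic ring of carbon leaves with the 4-fluorobenzyl group and a three-membered non-aromatic ring enters with cyclopropyl, and in this assay compound 3 gives a real number, 84000 nM, so the exchange shows no measurable rise in toxicity that can be claimed beyond the scatter. The true size of the step cannot be fixed, however, because the value of compound 1 is a limit of the test and not a number: the limit of > 100000 nM in this assay, at which 1 of the 3 values shown sits.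

As far as these compounds go, it remains open whether a group on this nitrogen that carries an amine or a carboxylic acid, or a longer chain such as n-hexyl, would shift the read-out beyond the scatter. Also open, from the compounds shown here alone, is whether cyclopropyl on this nitrogen would give the same picture on the core of compound 2, with its tert-butyl group on the other amide-type nitrogen.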